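From Dimethylphenyl to Chlorophenyl on a Sulfonamide Nitrogen

The source may report more compounds than this note shows. Statements on the series, on what has been measured and on what is new or still open speak of the compounds shown alone.

In a functional assay on SK-OV-3 cells (Homo sapiens) for antiproliferative activity, read by sulforhodamine B assay, with a stated time of 48 h (a higher number here means a weaker inhibitor, a lower number a stronger inhibitor), three compounds sharing one core have been measured. Compound 1 `CCc1cccc(NS(=O)(=O)c2ccc(N3CCNC3=O)cc2)c1` gives 230 nM and compound 2 `O=C1NCCN1c1ccc(S(=O)(=O)Nc2cccc(Br)c2)cc1` gives 170 nM while compound 3 `Cc1ccc(C)c(NS(=O)(=O)c2ccc(N3CCNC3=O)cc2)c1` gives 72 nM as the lowest number of the three, which makes it the strongest inhibitor of the set.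

Compound 4 `O=C1NCCN1c1ccc(S(=O)(=O)Nc2cccc(Cl)c2)cc1` has not been measured yet. Set against compound 3, it puts 3-chlorophenyl in place of 2,5-dimethylphenyl on a sulfonamide nitrogen and so gives up the group found only in compound 3.

The measurements show a 2.4-fold lower number from compound 2 to compound 3 (0.37 log units; beyond the scatter) and also a 3.2-fold lower number from compound 1 to compound 3 (0.50 log units; beyond the scatter) when 2,5-dimethylphenyl arrives on that nitrogen, and both steps are modest. The other two compounds sit close together, with a 1.4-fold lower number from compound 1 to compound 2 (0.13 log units; within the scatter) for bromo in place of ethyl. The 3-chlorophenyl group looks closest to the ring of compound 2 at 170 nM so a modest rise in the number is expected in this assay rather than a flat result. The expected size is a 2.6-fold higher number from compound 3 to compound 4 (0.42 log units; beyond the scatter) by this estimate. Compound 4 is estimated at 190 nM with an expected range of 90 nM to 380 nM around that estimate.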

Compound 4, half-maximal inhibitory concentration: 70 nM
For compound 4 the middle estimate is 2.7-fold (0.43 log units) above the measured one; the measured number lies below the stated range.
By their numbers in this assay, from the lowest: compounds 4 and 3 (each within the scatter of the next); then compounds 2 and 1 (each within the scatter of the next).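

Moving from the 2,5-dimethylphenyl group to 3-chlorophenyl on the sulfonamide nitrogen gives a 1.0-fold lower number from compound 3 to compound 4 (0.01 log units; within the scatter) in this assay so low numbers in this set are not confined to the 2,5-dimethylphenyl ring. Chloro also separates from the other single groups, as chloro in place of bromo gives a 2.4-fold lower number from compound 2 to compound 4 (0.39 log units; beyond the scatter) and chloro in place of ethyl gives a 3.3-fold lower number from compound 1 to compound 4 (0.52 log units; beyond the scatter) on the aromatic carbon, although compound 1 and compound 2 lie within the scatter of each other. No measurement at hand accounts for this difference between chloro and bromo.

The compounds shown leave open how a fluoro, a methoxy or an amine on that ring would read. They also leave open how a change to the shared core would read with either ring in place.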